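The compounds below may be only part of what the source reports. "The series", "measured", "known", "first", "only" and "open" are said of these compounds alone.

In an ADME assay on HEK-293T cells (Homo sapiens) for cytotoxicity, read by CCK-8 assay, with a stated time of 24 h (on this read-out lower numbers stand for higher toxicity in this test and higher numbers for lower toxicity in this test), compound 1 `COc1ccccc1CNC(=O)CSc1c[nH]c2c(-c3ccccc3)cccc12` gives 95500 nM. Compound 2 `O=C(CSc1c[nH]c2c(Br)cccc12)NCc1ccc(Cl)c(Cl)c1` reads > 100000 nM, which is a limit of the assay and not a number. Compound 3 `COc1ccccc1CN(C)C(=O)CSc1c[nH]c2ccccc12` reads > 100000 nM, which is also a limit. Compound 2 therefore stands at the limit of > 100000 nM in this assay, at which 2 of the 3 values shown sit. Compound 4 `COc1ccccc1CNC(=O)CSc1c[nH]c2c(Br)cccc12` has 2-methoxyphenyl in place of 3,4-dichlorophenyl on a saturated chain carbon bound to an amide-type nitrogen. Compounds 1 and 3 both carry the 2-methoxyphenyl group, and neither reads lower than the value of compound 1 at 95500 nM. In this assay the estimated a number no higher from compound 2 to compound 4 (the limit leaves the size open) is expected to stay within the usual scatter, in neither direction. Compound 4 is expected at about 100000 nM, with an estimated range from 55000 nM to 180000 nM.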

Compound 4, half-maximal cytotoxic concentration: 72400 nM
The estimate for compound 4 lay 1.4-fold (0.14 log units) above the measured number; the measured number falls inside the stated range.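

In this assay, 2-methoxyphenyl in place of 3,4-dichlorophenyl on a saturated chain carbon bound to an amide-type nitrogen brings an at least 1.3-fold lower number from compound 2 to compound 4 (0.14 log units; that floor lies within the scatter). The value of compound 2 is a limit of the assay and not a number, so the full size of this step stays open: the limit of > 100000 nM in this assay, at which 2 of the 4 values shown sit.
On an aromatic carbon, bromo in place of phenyl brings a 1.3-fold lower number from compound 1 to compound 4 (0.12 log units; within the scatter), so this exchange shows no change beyond the scatter. The compounds shown leave open what this assay would read with an amine or a carboxylic acid in place of 2-methoxyphenyl on that saturated chain carbon.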